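The source may report more compounds than this note shows. Statements on the series, on what has been measured and on what is new or still open speak of the compounds shown alone.

Measured so far, each value being a limit of the assay:
- Compound 1 `CCCCc1oc2ccccc2c1C(=O)c1ccc(OCC(=O)N2CCOCC2)cc1`: > 50000 nM
- Compound 2 `CCCCc1oc2ccccc2c1C(=O)c1ccc(OCC(=O)NCc2ccccc2)cc1`: > 50000 nM

In a functional assay on HL-60 cells (Homo sapiens) for antiproliferative activity, read by MTT assay, with a stated time of 24 h (on this read-out higher numbers stand for weaker inhibition and lower numbers for stronger inhibition), compound 2 gives > 50000 nM, which is a limit and not a number. Compound 1 gives > 50000 nM, which is also a limit. Both values shown therefore sit at the same ceiling: the limit of > 50000 nM in this assay, at which 2 of the 2 values shown sit.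

Compound 3 `CCCCc1oc2ccccc2c1C(=O)c1ccc(OCC(=O)N[C@H](C)c2ccccc2)cc1` keeps the shared core and changes only the amide side chain: methyl in place of hydrogen on a saturated chain carbon bound to an amide-type nitrogen and an aromatic carbon. In other words, benzylamino becomes (1-phenylethyl)amino.

Among the measured compounds shown here, only one measured step bears on this change, a step that the two limits leave unreadable from compound 1 to compound 2. It replaced morpholin-4-yl with benzylamino on the same carbonyl carbon, and it gives no size to carry over. For the measured compounds named here, no measured compound yet shows a number in this assay, so nothing points to a gain from the added methyl. The expectation rests on compound 2 at > 50000 nM, and no step beyond the scatter is expected in this assay, in either direction.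

The estimate for the change is a number no higher from compound 2 to compound 3 (the limit leaves the size open). Compound 3 is expected at about 50000 nM, with an estimated range from 20000 nM to 100000 nM, and it may well be reported only as a limit.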

Compound 3, half-maximal inhibitory concentration: > 50000 nM
Compound 3 gave a limit, no number; the forecaster's own chance of this, stated with the estimate: 85%; the middle value sits exactly at the limit.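

In this assay compound 3 gives > 50000 nM, which is a limit and not a number. Among the compounds shown here, no step among compound 1, compound 2 and compound 3 can therefore be read, as all three stand at one ceiling: the limit of > 50000 nM in this assay, at which 3 of the 3 values shown sit. The compounds shown leave open whether any amide side chain on the shared core would give a measurable value in this assay.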